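Amide side-chain variation in a small cytotoxicity series

The source may hold more compounds than are shown below. What is called first, only, known or untested is meant among the compounds shown, and "the series" means these compounds.

compound 1 `COC(=O)CCNC(=O)Cn1cc(C2=C(c3c[nH]c4ccccc34)C(=O)N(C)C2=O)c2ccccc21`: 47800 nM
compound 2 `COC(=O)[C@H](NC(=O)Cn1cc(C2=C(c3c[nH]c4ccccc34)C(=O)N(C)C2=O)c2ccccc21)C(C)C`: 16000 nM

In a functional assay on MCF7 cells (Homo sapiens) for cytotoxicity, read by MTT assay, with a stated time of 24 h (a lower number here means a stronger inhibitor, a higher number a weaker inhibitor), compound 1 gives 47800 nM, and in this assay compound 2 gives 16000 nM. Within the data shown here, compound 2 stands lowest of the two numbers, the only measured comparison being a 3.0-fold lower number from compound 1 to compound 2 (0.48 log units; beyond the scatter).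

Compound 3 `COC(=O)[C@@H](CO)NC(=O)Cn1cc(C2=C(c3c[nH]c4ccccc34)C(=O)N(C)C2=O)c2ccccc21` is not yet measured. It differs from compound 2 by hydroxymethyl in place of isopropyl on a saturated chain carbon bound to an amide-type nitrogen and a carbonyl carbon. Among the measured compounds shown here, no measured step bears directly on this exchange: the single step of a 3.0-fold lower number from compound 1 to compound 2 (0.48 log units; beyond the scatter) changes the substituent on the amide-type nitrogen as a whole and does not isolate the isopropyl. The two measured numbers span a narrow window, so a small step is expected in this assay, most likely toward a somewhat higher number, with wide uncertainty. The step from compound 2 to compound 3 is expected to be a 1.6-fold higher number from compound 2 to compound 3 (0.19 log units; within the scatter). Compound 3 is accordingly estimated at 25000 nM, in the range 9000 nM to 70000 nM.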

Compound 3, half-maximal inhibitory concentration: 24500 nM
Compound 3: the middle estimate sits 1.0-fold (0.01 log units) above what was measured, and the stated range covers the measured number.
By their numbers in this assay, from the lowest: compounds 2, 3 and 1 (each within the scatter of the next, the first and the last beyond it).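

In this assay, hydroxymethyl in place of isopropyl on a saturated chain carbon bound to an amide-type nitrogen and a carbonyl carbon gives a 1.5-fold higher number from compound 2 to compound 3 (0.19 log units; within the scatter) and so does not separate the two compounds, although a hydrogen-bond donor and acceptor enter with it. The 2-hydroxy-1-(methoxycarbonyl)ethyl group in place of 2-(methoxycarbonyl)ethyl on the amide-type nitrogen gives a 2.0-fold lower number from compound 1 to compound 3 (0.29 log units; within the scatter) and so leaves compound 3 unresolved from both neighbours, while the larger step of a 3.0-fold lower number from compound 1 to compound 2 (0.48 log units; beyond the scatter) remains the only one beyond the scatter. No measurement at hand accounts for these numbers.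

Open, as far as these compounds go, is whether an amine or a longer chain at this chain carbon would give a step beyond the scatter. Also open, from the compounds shown here alone, is how a carboxylic acid in place of the methyl ester would read in this assay.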